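From compound 3 to compound 4 at the dopamine receptor

This account rests on a few compounds, and the source may have more. Where it says the series, first, only, none or still open, it means among the compounds named here.

Of the compounds shown here, three have been measured in a functional assay on HEK293 cells for agonist activity at D(4) dopamine receptor (Homo sapiens), read by FLIPR; on this read-out lower numbers stand for smaller maximal responses and higher numbers for larger maximal responses. Compound 1 `O=C(CN1CCC(c2cccc[n+]2[O-])CC1)Nc1cccc(C(F)(F)F)c1` gives 75%, compound 2 `CCc1cccc(C)c1NC(=O)CN1CCC(c2ccccn2)CC1` gives 70%, and compound 3 `COc1cccc(C)c1NC(=O)CN1CCC(c2cccc[n+]2[O-])CC1` gives 56%. On these numbers compound 3 stands lowest: compound 2 is nearest and compound 1 furthest, and both gaps lie beyond the usual scatter. Compound 4 `COc1cccc(C)c1NC(=O)CN1CCC(c2ccccn2)CC1` has not been measured yet. It differs from compound 3 in one place: a group of 6 heavy atoms (5 carbon, 1 nitrogen; one six-membered aromatic ring with 1 hetero atom) in place of a group of 7 heavy atoms (5 carbon, 1 nitrogen, 1 oxygen; one six-membered aromatic ring with 1 hetero atom), on a saturated ring carbon. Within the data shown here, no measured pair shows this single change, so its size is uncertain; compound 2, which carries the same pyridin-2-yl group, gives 70% in this assay. Compound 4 is expected to reach about 63%, between 47% and 79%. The expected step of a number 7 percentage points higher from compound 3 to compound 4 (within the scatter) is a modest rise, possibly within the scatter.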

Compound 4, largest response reached (reported as efficacy), in percent of the reference or control that the assay uses: 69%
Compound 4: the middle estimate sits 6 percentage points below what was measured, and the stated range covers the measured number.
By their numbers in this assay, from the lowest: compound 3; then compounds 4, 2 and 1 (each within the scatter of the next).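

In this assay, pyridin-2-yl in place of the oxygen-bearing group of 7 heavy atoms on the saturated ring carbon gives a direct reading of this change: a number 13 percentage points higher from compound 3 to compound 4 (beyond the scatter). On the aromatic carbon, methoxy in place of ethyl gives a number 1 percentage points lower from compound 2 to compound 4 (within the scatter), so this second change shows no difference that can be read. Nothing here explains why the first change raises the maximal response. From the compounds shown here alone, whether the same rise would appear with the trifluoromethyl group of compound 1 remains open. So does the response with a plain phenyl ring, which has no ring nitrogen, at this ring carbon.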